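A few compounds are considered here, and "the series" means these few. Any claim that something is new, unique, unknown or untested is made for them only; others in the source may bear on it.

Measured in a functional assay on MOLT-4 cells (Homo sapiens) for antiproliferative activity, read by MTT assay, with a stated time of 3 days; a higher number here means a weaker inhibitor, a lower number a stronger inhibitor:
- Compound 1 `O=C1c2ccccc2C(=O)N1C/C=C\Cn1cc(C#Cc2ccc(Br)cc2)c(=O)[nH]c1=O`: 89000 nM
- Compound 2 `CCCCCC#Cc1cn(C/C=C/CN2C(=O)c3ccccc3C2=O)c(=O)[nH]c1=O`: > 500000 nM

Among the measured compounds shown here, compound 1 is the only compound in this small set with a measured number, and in this assay compound 1 gives 89000 nM. Compound 2 is recorded at > 500000 nM, which is a limit of the assay and not a number.

Compound 3 `O=C1c2ccccc2C(=O)N1C/C=C\Cn1cc(C#CCCc2ccccc2)c(=O)[nH]c1=O`, not yet measured, keeps the core of compound 1 and changes one group: phenethyl in place of 4-bromophenyl on a triple-bonded carbon. In words, it has phenethyl in place of 4-bromophenyl on a triple-bonded carbon. For the measured compounds named here, no measured step between compounds that differ in one place is available to size this change. Only a modest shift toward weaker inhibition is therefore expected, and the expected change is a 1.3-fold higher number from compound 1 to compound 3 (0.13 log units; within the scatter). Compound 3 is estimated at 120000 nM, with an expected range from 40000 nM to 400000 nM.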

Compound 3, half-maximal inhibitory concentration: 146000 nM
Compound 3: middle estimate off by 1.2-fold (0.09 log units), on the low side; low and high end bracket the measured number.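

In this assay, phenethyl in place of 4-bromophenyl on a triple-bonded carbon gives a 1.6-fold higher number from compound 1 to compound 3 (0.21 log units; within the scatter). Among the compounds shown here, this is the first step that can be sized at this place, and it shows that the two groups cannot be told apart here, although one carries bromine and the other does not. For the compounds shown here, nothing measured so far offers a cause for this result.

Going by these compounds, whether an amine or a carboxylic acid on the same triple-bonded carbon would move the number beyond the scatter stays open, as does the effect of a substituent other than bromine on the aromatic ring. Going by these compounds alone, compound 2 differs from compound 1 in more than one place and its value is a limit of the assay and not a number, so it sizes no step.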